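A few compounds are considered here, and "the series" means these few. Any claim that something is new, unique, unknown or untested is made for them only; others in the source may bear on it.

Compound 1 `N[C@@H]1CCN(c2cc3c(cc2F)c(=O)c(C(=O)O)cn3Cc2ccc(-c3ccccc3)cc2)C1` gives 63600 nM in an assay on isolated protein for inhibition of DNA topoisomerase 1 (Homo sapiens), with a stated time of 15 min; on this read-out higher numbers stand for weaker inhibition and lower numbers for stronger inhibition.
Compound 2 `O=C(O)c1cn(Cc2ccc(-c3ccccc3)cc2)c2cc(NC[C@@H]3CCNC3)c(F)cc2c1=O` gives 104000 nM.
Compound 3 `CNCCCNc1cc2c(cc1F)c(=O)c(C(=O)O)cn2Cc1ccc(-c2ccccc2)cc1` gives 63600 nM.

Three compounds share one core and differ only in the amine-bearing group on one aromatic carbon. Compound 3 stands level with compound 1: no change at the digits printed from compound 1 to compound 3 (within the scatter). Against compound 2 the picture is the same, since a 1.6-fold lower number from compound 2 to compound 3 (0.21 log units; within the scatter), and likewise a 1.6-fold higher number from compound 1 to compound 2 (0.21 log units; within the scatter). None of the three exchanges at this position has moved the read-out beyond what repeated measurement of the same compound would show.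

Compound 4 `O=C(O)c1cn(Cc2ccc(-c3ccccc3)cc2)c2cc(N3C[C@H]4CCNC[C@H]4C3)c(F)cc2c1=O` is the next variation at the same place: a group of 9 heavy atoms (7 carbon, 2 nitrogen; one five-membered non-aromatic ring with 1 hetero atom, one six-membered non-aromatic ring with 1 hetero atom) in place of a group of 6 heavy atoms (4 carbon, 2 nitrogen; no ring), on an aromatic carbon. The most telling precedent is the step from compound 1 to compound 3, where a ring-containing amine was swapped for an open chain without any change, and the two other steps, each small and within the scatter, point the same way. The change to compound 4 again exchanges one amine-bearing group for another on that carbon, so the expected step is a 1.0-fold higher number from compound 3 to compound 4 (0.01 log units; within the scatter), with no shift beyond the scatter in either direction. Compound 4 is therefore estimated to give 65000 nM, with a plausible range from 25000 nM to 170000 nM.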

Compound 4, half-maximal inhibitory concentration: 61000 nM
Compound 4: middle estimate off by 1.1-fold (0.03 log units), on the high side; the measured number falls inside the stated range.
By their numbers in this assay, from the lowest: compounds 4, 1, 3 and 2 (each within the scatter of the next).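

Among these compounds, compound 4 brings the first group with two fused rings, 9 heavy atoms and 2 defined stereocentres to this aromatic carbon, and in this assay the change gives a 1.0-fold lower number from compound 3 to compound 4 (0.02 log units; within the scatter); the comparisons with the other two compounds give a 1.0-fold lower number from compound 1 to compound 4 (0.02 log units; within the scatter) and a 1.7-fold lower number from compound 2 to compound 4 (0.23 log units; within the scatter). The earlier compounds shown here had covered only an open chain and groups with one five-membered ring, so the read-out now stays level across a wider range of amine shapes and sizes, and also when the count of hydrogen-bond donors changes from 2 to 1 between compound 3 and compound 4. No separate measurement is available to explain why these four values stay level.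

As far as these compounds go, all four groups at this carbon contain two nitrogens, so it remains open whether a group without an amine, such as methoxy or a simple carboxylic acid, would shift the number beyond the scatter. From the compounds shown here alone, the fluoro group and the carboxylic acid on the shared core are also the same throughout, so the effect of replacing either one, for example the acid with an amide, remains unknown.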